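Chloro in Place of Methyl on Two Different Cores

The source may hold more compounds than are shown below. What is called first, only, known or untested is meant among the compounds shown, and "the series" means these compounds.

Four compounds share an amide with a tertiary amine on a ring, and differ in the aromatic substituent and the core. Compound 1 `CCC(=O)N(c1ccc(Cl)cc1)C1CCCCC1N(C)C`, compound 2 `CCC(=O)N(c1ccc(C)cc1)C1CCCCC1N(C)C` and compound 3 `CCC(=O)N(c1ccccc1C)C1CCCC1N(C)C` have been tested in a functional assay on the whole organism for positive allosteric modulation, with Mus musculus as the target; a lower number here means that less compound is needed, a higher number that more compound is needed for the effect. In this assay compound 1 gives 35 mg/kg. Compound 2 reaches only a limit of the assay, > 50 mg/kg, so no number is known for it; (the limit of > 50 mg/kg in this assay, at which 1 of the 3 values shown sits). The change chloro in place of methyl on an aromatic carbon gave an at least 1.4-fold lower number from compound 2 to compound 1 (0.15 log units; that floor lies within the scatter). Compound 3 gives 7 mg/kg in this assay; how its core differs from that of compound 2 is not broken down here.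

Compound 4 `CCC(=O)N(c1ccccc1Cl)C1CCCC1N(C)C` has not yet been measured. It differs from compound 3 by chloro in place of methyl on an aromatic carbon. This is the same kind of change as from compound 2 to compound 1, but the place differs: there it was para to a large group, here ortho to a large group. Because the earlier step of an at least 1.4-fold lower number from compound 2 to compound 1 (0.15 log units; that floor lies within the scatter) stayed within the usual scatter, the expected step is a 1.2-fold lower number from compound 3 to compound 4 (0.07 log units; within the scatter). Compound 4 is therefore estimated at 6 mg/kg, between 2.5 mg/kg and 15 mg/kg.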

Compound 4, dose for half-maximal effect: 6 mg/kg
Estimate against measurement, compound 4: no gap at the digits printed; low and high end bracket the measured number.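

In this assay, chloro in place of methyl on an aromatic carbon, ortho to a large group, gave a 1.2-fold lower number from compound 3 to compound 4 (0.07 log units; within the scatter), and on this core the two groups cannot be told apart. This does not show whether the change carries over from one core to the other by the same amount, and the group also sits in a different place on each core: the same change on two cores in this assay, an at least 1.4-fold lower number (0.15 log units; that floor lies within the scatter) from compound 2 to compound 1 and a 1.2-fold lower number (0.07 log units; within the scatter) from compound 3 to compound 4; the limit leaves it open whether they differ. Compound 2 gives only a limit of the assay, > 50 mg/kg, and not a number.

The compounds shown leave open whether other groups in the same place, such as fluoro, methoxy or trifluoromethyl, would give numbers like those of compound 3 and compound 4. They also leave open how chloro and methyl would compare ortho to a large group on the core of compound 1, a comparison that would separate the role of the core from that of the place.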